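A few compounds are considered here, and "the series" means these few. Any claim that something is new, unique, unknown or untested is made for them only; others in the source may bear on it.

Measured compounds in the series so far:

compound 1 `CCCN(CCC)c1cnc(-c2c(C)cc(C)cc2OC)c2ccccc12` — 49 nM
compound 2 `CCCN(CC1CC1)c1c(C)nc(-c2c(C)cc(C)cc2OC)c2ccccc12` — 5 nM

Both numbers come from an in vitro assay on IMR-32 cells for displacement of a labelled ligand from corticotropin-releasing factor receptor 1 (Homo sapiens); on this read-out higher numbers stand for weaker inhibition and lower numbers for stronger inhibition. Compound 1 stands at the highest of the two numbers; the nearest is compound 2, whose value lies beyond the scatter of compound 1. Among the measured compounds shown here, compound 2 differs from compound 1 in two places at once, so no single step connects them; its value shows only that the combined change is paired with the stronger binding.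

Compound 3 `CCCN(CCC)c1c(CC)nc(-c2c(C)cc(C)cc2OC)c2ccccc12` has not yet been measured in this assay. It differs from compound 1 by one change: ethyl in place of hydrogen on an aromatic carbon. For the measured compounds named here, compound 2, with 5 nM, carries a methyl at the same aromatic carbon, and an alkyl there goes together with the lower number in the one comparison available, although the amine in compound 2 also differs, so the share of that position in the drop is not settled. On that basis a drop beyond the scatter is expected for compound 3, short of the number seen for compound 2. Compound 3 is expected to give 12 nM in this assay, within a range from 4 nM to 40 nM. That estimate means an expected step of a 4.1-fold lower number from compound 1 to compound 3 (0.61 log units; beyond the scatter).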

Compound 3, inhibition constant: 9 nM
Compound 3: middle estimate off by 1.3-fold (0.12 log units), on the high side; the measured number falls inside the stated range.
By their numbers in this assay, from the lowest: compounds 2 and 3 (each within the scatter of the next); then compound 1.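

In this assay, among the compounds shown here, the step of a 5.4-fold lower number from compound 1 to compound 3 (0.74 log units; beyond the scatter) is the first reading of this position on its own: ethyl in place of hydrogen on an aromatic carbon next to the ring nitrogen, with the dipropylamino group the same on both sides. Compound 1 and compound 2 differ in two places, so that pair could not separate this carbon from the amine; the lower number now goes with the ethyl alone, on the dipropylamino background and the shared core. The data offer no measurement that would account for the size of this step.

The compounds shown leave open how far the step depends on the group itself: whether a methyl, a propyl or longer chain, or a group of another kind such as methoxy or an amine, on this carbon gives a step of similar size on the dipropylamino background. Also open, from the compounds shown here alone, is what the amine contributes alone, which would take a pair differing only in dipropylamino against the propyl(cyclopropylmethyl)amino group of compound 2.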